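The source may report more compounds than this note shows. Statements on the series, on what has been measured and on what is new or still open speak of the compounds shown alone.

Measured compounds:
compound 1 `O=c1[nH]/c(=N\OCCCCc2ccccc2)ccn1[C@@H]1O[C@H](COP(=O)(O)OP(=O)(O)OP(=O)(O)O)[C@@H](O)[C@H]1O`: 251 nM
compound 2 `O=c1[nH]/c(=N\OCCOc2ccccc2)ccn1[C@@H]1O[C@H](COP(=O)(O)OP(=O)(O)OP(=O)(O)O)[C@@H](O)[C@H]1O`: 1780 nM
compound 3 `O=c1[nH]/c(=N\OCCCc2cccc(I)c2)ccn1[C@@H]1O[C@H](COP(=O)(O)OP(=O)(O)OP(=O)(O)O)[C@@H](O)[C@H]1O`: 299 nM

In a functional assay on 1321-N1 cells for agonist activity at P2Y purinoceptor 6 (Homo sapiens), read by scintillation counting and inositol phosphate accumulation (a lower number here means that less compound is needed, a higher number that more compound is needed for the effect), compound 3 gives 299 nM. Its nearest neighbour is compound 1, with a 1.2-fold higher number from compound 1 to compound 3 (0.08 log units; within the scatter), and its furthest is compound 2, with a 6.0-fold lower number from compound 2 to compound 3 (0.77 log units; beyond the scatter). Compound 4 `O=c1[nH]/c(=N\OCCCc2ccc([N+](=O)[O-])cc2)ccn1[C@@H]1O[C@H](COP(=O)(O)OP(=O)(O)OP(=O)(O)O)[C@@H](O)[C@H]1O` differs from compound 3 by 4-nitrophenyl in place of 3-iodophenyl on a saturated chain carbon, three bonds along the chain from an oxygen. Among the measured compounds shown here, no measured step exchanges one substituted phenyl for another; the one step that touches this ring read a 1.2-fold higher number from compound 1 to compound 3 (0.08 log units; within the scatter), whereas the larger step, a 7.1-fold higher number from compound 1 to compound 2 (0.85 log units; beyond the scatter), concerns the chain rather than the ring. Compound 4 is therefore expected to stay near compound 3, with an estimated 1.3-fold higher number from compound 3 to compound 4 (0.13 log units; within the scatter), a shift not expected to reach beyond the scatter. The estimated value of compound 4 is 400 nM, within a range from 150 nM to 1200 nM.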

Compound 4, half-maximal effective concentration: 1330 nM
Compound 4: the middle estimate sits 3.3-fold (0.52 log units) below what was measured; the whole stated range lies below it.
By their numbers in this assay, from the lowest: compounds 1 and 3 (each within the scatter of the next); then compounds 4 and 2 (each within the scatter of the next).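

In this assay, exchanging 3-iodophenyl for 4-nitrophenyl at this place on the chain is not a silent change, with a 4.4-fold higher number from compound 3 to compound 4 (0.65 log units; beyond the scatter) and a 5.3-fold higher number from compound 1 to compound 4 (0.72 log units; beyond the scatter). A change on the ring alone therefore brings compound 4 level with compound 2, at a 1.3-fold lower number from compound 2 to compound 4 (0.13 log units; within the scatter), so the ring substituent matters here as well as the chain. No evidence is at hand to account for this shift.

On these data alone, whether the shift follows the nitro group itself or its place on the ring stays open, as compound 4 differs from compound 3 in both. As far as these compounds go, how an amine or a carboxylic acid on that ring would read also remains open.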